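Halogenated benzylidene replaces trimethoxyphenyl on the hydrazone arm

The source may report more compounds than this note shows. Statements on the series, on what has been measured and on what is new or still open speak of the compounds shown alone.

For the measured compounds named here, compound 3 `COc1cc(/C=N/NC(=O)Nc2ccc(Oc3ccnc(-c4nncn4CCN(C)C)c3)c(F)c2)cc(OC)c1OC` is one of three compounds measured in a functional assay on A549 cells (Homo sapiens) for cytotoxicity, read by MTT assay, with a stated time of 72 h; on this read-out higher numbers stand for weaker inhibition and lower numbers for stronger inhibition. In this assay compound 3 gives only a limit, > 100000 nM, and not a number. The same holds for compound 2 `Cn1ncnc1-c1cc(Oc2ccc(NC(=O)N/N=C/c3ccccc3)cc2F)ccn1`, which in this assay gives the limit > 100000 nM. Compound 1 `COc1ccc(/C=N/NC(=O)Nc2ccc(Oc3ccnc(-c4nncn4CCN(C)C)c3)c(F)c2)c(OC)c1OC` gives 6680 nM in this assay, and the step of an at least 14-fold higher number from compound 1 to compound 3 (1.17 log units; beyond the scatter) shows how much the arrangement of the three methoxy groups matters at this position. Compound 3 therefore stands at the limit of > 100000 nM in this assay, at which 2 of the 3 values shown sit, with no number of its own.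

Compound 4 `CN(C)CCn1cnnc1-c1cc(Oc2ccc(NC(=O)N/N=C/c3ccc(F)cc3Cl)cc2F)ccn1` differs from compound 3 by 2-chloro-4-fluorophenyl in place of 3,4,5-trimethoxyphenyl on a carbon with a double bond to nitrogen. Going by the values given here, no measured step covers this exchange; the only step at the same place is the large one from compound 1 to compound 3, and compound 2, bearing a plain phenyl there, also sits at the limit. A weak outcome is expected; the step of an at least 1.6-fold lower number from compound 3 to compound 4 (0.22 log units; that floor lies within the scatter) is the estimated change, though the limit may again be reached. For compound 4 in this assay the estimate is 60000 nM, expected to fall between 8000 nM and 200000 nM.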

Compound 4, half-maximal inhibitory concentration: 1120 nM
The estimate for compound 4 lay 54-fold (1.73 log units) above the measured number, and the stated range ends above it.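

The earlier compounds shown here showed only that the arrangement of the three methoxy groups matters at this position; compound 4 shows that a ring with no methoxy group can do better than either arrangement in this assay. The 2-chloro-4-fluorophenyl group gives an at least 89-fold lower number from compound 3 to compound 4 (1.95 log units; beyond the scatter), and it also improves on the better trimethoxyphenyl isomer, with a 6.0-fold lower number from compound 1 to compound 4 (0.78 log units; beyond the scatter). Compound 4 gives a measured number and does not join the compounds held at the assay limit: the limit of > 100000 nM in this assay, at which 2 of the 4 values shown sit.

The compounds shown cannot separate the contributions of the chlorine and the fluorine, which a ring with only one of these halogens, or with a bromine or a nitrile, could address. On these data alone, it also remains open whether the 2-chloro-4-fluorophenyl group would keep this effect with a plain methyl in place of the dimethylaminoethyl chain.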